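The compounds below may be only part of what the source reports. "The series", "measured", "known", "first", "only" and "open" are said of these compounds alone.

The measured compounds:
compound 1, `COc1cc2nc(/C=C/c3ccccc3)nc(N3CCC(CCNS(N)(=O)=O)CC3)c2cc1OC`: 33%
compound 2, `COc1cc2nc(/C=C/c3ccccc3F)nc(N3CCC(CCNS(N)(=O)=O)CC3)c2cc1OC`: 78%

Both numbers come from an assay on cells for inhibition of Ectonucleotide pyrophosphatase/phosphodiesterase family member 1 (Homo sapiens), with a stated time of 60 min, tested at 1 uM; a lower number here means less inhibition, a higher number more inhibition at the concentration tested (going by the name of the read-out). Compound 2 stands highest of the two values in this assay; its nearest neighbour is compound 1, and the gap is a number 45 percentage points higher from compound 1 to compound 2 (beyond the scatter), a large step that goes with a single change, fluoro in place of hydrogen on an aromatic carbon. Compound 3, `COc1cc2nc(/C=C/c3cccc(F)c3)nc(N3CCC(CCNS(N)(=O)=O)CC3)c2cc1OC`, has not yet been measured in this assay. It shares every atom with compound 2 and differs only in how they are joined: 3-fluorophenyl in place of 2-fluorophenyl on a double-bonded chain carbon bound to a double-bonded chain carbon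

Among the measured compounds shown here, only one measured step bears on this change, the one from compound 1 to compound 2, and it concerned the arrival of a fluorine, not its shift from 2-fluorophenyl to 3-fluorophenyl. Nothing measured covers that shift itself, so compound 3 could sit anywhere between the two known values or beside compound 2. The expected step, a number 23 percentage points lower from compound 2 to compound 3 (beyond the scatter), is therefore a moderate fall, held with wide uncertainty. Compound 3 is estimated to give 55% in this assay, within a range of 25% to 85%.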

Compound 3, a percentage reported as inhibition, at one concentration (the size of the read-out at that concentration, not a potency): 14%
Compound 3: the middle estimate sits 41 percentage points above what was measured; the whole stated range lies above it.
By their numbers in this assay, from the lowest: compound 3; then compound 1; then compound 2.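

In this assay, shifting the fluorine from 2-fluorophenyl to 3-fluorophenyl on a double-bonded chain carbon bound to a double-bonded chain carbon gives a number 64 percentage points lower from compound 2 to compound 3 (beyond the scatter) and shows that the earlier gain did not come with the fluoro group wherever it stands. Fluoro in place of hydrogen can now go either way at this aromatic ring: a number 45 percentage points higher from compound 1 to compound 2 (beyond the scatter) stands for the 2-fluorophenyl compound, whereas a number 19 percentage points lower from compound 1 to compound 3 (beyond the scatter) stands for the 3-fluorophenyl compound, so the outcome of this change depends on which of the two groups results, even though both have the same atoms and the same counts. No measurement offered here accounts for this reversal.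

The compounds shown leave open where 4-fluorophenyl would fall and whether 2-chlorophenyl or 2-methoxyphenyl would follow 2-fluorophenyl or the unsubstituted phenyl of compound 1. They also leave open whether the large gap between 2-fluorophenyl and 3-fluorophenyl would persist if the shared core carried a carboxylic acid or an amine on its chain.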